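Working notes: from compound 1 to bromo compound 4

The source may hold more compounds than are shown below. What is called first, only, known or untested is meant among the compounds shown, and "the series" means these compounds.

Values measured so far in an ADME assay on HEp-2 cells (Homo sapiens) for cytotoxicity; a lower number here means that less compound is tolerated, a higher number that more compound is tolerated
compound 1 `CC(C)CCn1c(Cn2c(=O)n(C(C)C)c3ccccc32)nc2cc(CNC3CC3)ccc21` gives 17200 nM
compound 2 `CC(C)CCn1c(Cn2c(=O)n(C(C)C)c3ccccc32)nc2ccc(CN(C)C)cc21` gives 26700 nM
compound 3 `CC(C)CCn1c(Cn2c(=O)n(C(C)C)c3ccccc32)nc2c(CO)cccc21` gives 22000 nM

In this assay compound 1 stands at 17200 nM and cannot be separated from the other two. Compound 2 and compound 3 both lie within the scatter of it, so no order among the three can be read from these numbers. No two of them differ in one place only, which leaves no single change with a measured size.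

The next compound is compound 4 `CC(C)CCn1c(Cn2c(=O)n(C(C)C)c3ccccc32)nc2cc(Br)ccc21` which carries bromo in place of (cyclopropylamino)methyl on an aromatic carbon of the shared core (bromo in place of (cyclopropylamino)methyl on an aromatic carbon). Within the data shown here, no measured compound carries bromo, so the data say nothing direct about this group. The measured compounds do carry different groups on the shared core, yet compound 2 (26700 nM) and compound 3 (22000 nM) stay close to compound 1. On that basis the expected step (a 1.3-fold higher number from compound 1 to compound 4 (0.11 log units; within the scatter)) stays within the scatter, and the data support no firm direction for it. Compound 4 is expected at 22000 nM (estimated range 10000 nM to 50000 nM).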

Compound 4, half-maximal cytotoxic concentration: 18100 nM
Beside the measured number, compound 4's estimate is 1.2-fold (0.08 log units) above it; measured number inside the range.
By their numbers in this assay, from the lowest: compounds 1, 4, 3 and 2 (each within the scatter of the next).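

Among these compounds, the step of a 1.1-fold higher number from compound 1 to compound 4 (0.02 log units; within the scatter) is the first single change with a measured size, read in this assay, and it lies within the scatter. At this aromatic carbon, meta to a fused ring and para to a fused ring, the (cyclopropylamino)methyl group with its 5 heavy atoms, three-membered ring, hydrogen-bond donor and hydrogen-bond acceptor gives way to bromo, a single heavy atom with no ring, donor or acceptor, and no separable shift appears. No supporting evidence bears on this result.

Among the compounds shown here, whether a carboxylic acid or a longer alkyl chain on this same aromatic carbon would also stay within the scatter of compound 1 remains open, as the only two groups compared here are (cyclopropylamino)methyl and bromo. For the compounds shown here, also open is how bromo would read on the aromatic carbons that carry the side groups of compound 2 and compound 3, and no pair differing in one place covers those carbons.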